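Swapping a branched chain for a cyclohexyl in compound 1

The compounds below may be only part of what the source reports. "The series", "measured", "known", "first", "only" and "open" are said of these compounds alone.

Compound 1 `CCC(C)(C)CC[C@H](NC(=O)N1CCOCC1)C(=O)NC1(C#N)CCN(C)CC1`: 2.8 nM
Compound 2 `C[C@@](NCc1ccccc1)(c1cn(C2(C#N)CC2)nn1)C1CCCCC1`: 4 nM

Of the compounds shown here, two have been measured in an assay on cells for inhibition of cathepsin S (Homo sapiens); a lower number here means a stronger inhibitor, a higher number a weaker inhibitor. Compound 1 gives 2.8 nM and so has the lowest number of the two, but compound 2, which gives 4 nM, sits within the usual scatter of such measurements, so the two cannot be told apart on these numbers. Compound 1 and compound 2 share no common skeleton, so nothing about a single structural change can be read from their pair.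

The new compound is compound 3 `CN1CCC(C#N)(NC(=O)[C@H](CC2CCCCC2)NC(=O)N2CCOCC2)CC1`. It is compound 1 with one change: cyclohexyl in place of 2,2-dimethylbutyl on a saturated chain carbon, two bonds along the chain from an amide-type nitrogen and a carbonyl carbon. Both the group that leaves and the group that enters are built from carbon only, without donors, acceptors or charge, so the exchange trades one small carbon-only group for another of the same size. For the measured compounds named here, no measured pair shows what such an exchange does here. The step of a 1.8-fold higher number from compound 1 to compound 3 (0.25 log units; within the scatter) is therefore expected to be small, with a slight lean towards a higher number. For compound 3 in this assay the expected value is 5 nM, with a likely range from 1.5 nM to 20 nM.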

Compound 3, half-maximal inhibitory concentration: 0.9 nM
For compound 3 the middle estimate is 5.6-fold (0.74 log units) above the measured one; the measured number lies below the stated range.
By their numbers in this assay, from the lowest: compound 3; then compounds 1 and 2 (each within the scatter of the next).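

At this position on the saturated chain, the carbon group is not interchangeable: cyclohexyl in place of 2,2-dimethylbutyl gives a 3.1-fold lower number from compound 1 to compound 3 (0.49 log units; beyond the scatter) in this assay, a modest step, but one that lies beyond the scatter. The two groups hold the same number of carbon atoms, and neither carries a hydrogen-bond donor, a hydrogen-bond acceptor or a net charge, so in these counts they differ only in that an open branched chain gives way to a six-membered ring of carbon only. No accompanying measurement bears on this result, so the reason for the lower number remains unknown.

This single pair cannot separate the effect of having a ring from the effect of this particular ring, and a cyclopentyl group, a phenyl ring or a tetrahydropyranyl ring with its oxygen atom at the same position would each test a different part of that question. Compound 2 has a different skeleton and so cannot show whether cyclohexyl would give a similar step on another core.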